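A few compounds are considered here, and "the series" means these few. Any claim that something is new, unique, unknown or untested is made for them only; others in the source may bear on it.

Compound 3, `COc1ccc(/C=C\C(=O)O)c(OCc2cn(-c3ccccc3)nn2)c1CC=C(C)C`, was tested in a functional assay on COLO 205 cells (Homo sapiens) for cytotoxicity, read by MTT assay, with a stated time of 24 h (a higher number here means a weaker inhibitor, a lower number a stronger inhibitor), where compound 3 gives 32300 nM. Going by the values given here, only one other number stands beside it. Compound 1, `COc1ccc(/C=C\C(=O)O)c(OCc2cn(-c3ccc(NC(C)=O)cc3)nn2)c1CC=C(C)C`, carries an acetamido group on an aromatic carbon where compound 3 has a hydrogen, and compound 1 gives 22600 nM. Compound 2, `COc1cccc(-n2cc(COc3c(/C=C\C(=O)O)ccc(OC)c3CC=C(C)C)nn2)c1`, belongs to the same set, but in this assay compound 2 gives "not determined" (no result reported), so no number was obtained for it. Among the compounds with values here, the single step that joins two measured compounds runs a 1.4-fold higher number from compound 1 to compound 3 (0.16 log units; within the scatter), so these two numbers sit together within the usual spread of repeats and neither can be ranked against the other.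

Compound 4, `COc1ccc(/C=C\C(=O)O)c(OCc2cn(-c3ccc(C#N)cc3)nn2)c1CC=C(C)C`, differs from compound 3 in one place: cyano in place of hydrogen on an aromatic carbon. Within the data shown here, the only measured step that bears on this change is the exchange at the same aromatic carbon, a 1.4-fold higher number from compound 1 to compound 3 (0.16 log units; within the scatter), which stayed within the scatter. On that basis no step beyond the scatter is expected in this assay in either direction, and the expected step is a 1.1-fold lower number from compound 3 to compound 4 (0.03 log units; within the scatter). Compound 4 is therefore estimated at 30000 nM, with a range from 12000 nM to 75000 nM.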

Compound 4, half-maximal inhibitory concentration: 32000 nM
Compound 4: middle estimate off by 1.1-fold (0.03 log units), on the low side; the measured number falls inside the stated range.
By their numbers in this assay, from the lowest: compounds 1, 4 and 3 (each within the scatter of the next).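

In this assay, cyano on this aromatic carbon gives a 1.0-fold lower number from compound 3 to compound 4 (0.00 log units; within the scatter) and, set against acetamido at the same place, gives a 1.4-fold higher number from compound 1 to compound 4 (0.15 log units; within the scatter) with both steps within the scatter. The earlier compounds shown here compared only hydrogen and acetamido, whereas three different groups at this place, para to a large group, now give numbers that cannot be told apart, which extends the flat picture to a small group with a triple bond and no hydrogen-bond donor. Nothing available here accounts for this lack of separation.

The compounds shown leave open whether any group on this carbon can move the number beyond the scatter, for example an amine or a carboxylic acid. They also leave open whether a group at another carbon of that ring, such as methoxy, would do so.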